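This account rests on a few compounds, and the source may have more. Where it says the series, first, only, none or still open, it means among the compounds named here.

Measured compounds in a functional assay on UACC-257 cells (Homo sapiens) for inhibition, read by sulforhodamine B assay, with a stated time of 48 h, tested at 10 uM; a higher number here means a weaker effect of the compound at the concentration tested, a lower number a stronger effect:
- compound 1 `COc1cc(Cl)cc(-c2nn(-c3cccc(NC(=O)c4ccc(Cl)c(Cl)c4)c3)cc2-c2ccncc2)c1` gives 84.2%
- compound 2 `COc1cc(Cl)cc(-c2nn(-c3cccc(NC(=O)Nc4cc(C(F)(F)F)cc(C(F)(F)F)c4)c3)cc2-c2ccncc2)c1` gives -25.6%
- compound 3 `COc1cc(Cl)cc(-c2nn(-c3cccc(NC(=O)Nc4ccc(Cl)c(Cl)c4)c3)cc2-c2ccncc2)c1` gives -11.5%

Compound 3 stands second highest of the three numbers. Its nearest neighbour is compound 2, which lies lower by a gap beyond the scatter; the furthest is compound 1, which lies far higher. Among the measured compounds shown here, the one step recorded among the measured compounds is a number 95.7 percentage points lower from compound 1 to compound 3 (beyond the scatter), a replacement on the carbonyl carbon, and it is large.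

Compound 4 `COc1cc(Cl)cc(-c2nn(-c3cccc(NC(=O)Nc4cccc(C(F)(F)F)c4)c3)cc2-c2ccncc2)c1` has not yet been measured in this assay. It differs from compound 3 by 3-(trifluoromethyl)phenyl in place of 3,4-dichlorophenyl on an amide-type nitrogen, a swap of the aryl group on the amide-type nitrogen while the carbonyl and the rest of the core stay unchanged. For the measured compounds named here, no measured step describes such an aryl swap on that nitrogen. The step from compound 1 to compound 3 concerns a different position and does not bear on it. What the data do show is that compound 2, carrying a 3,5-bis(trifluoromethyl)phenyl group on the same nitrogen, and compound 3 both give strongly negative numbers, with compound 2 lower by a gap beyond the scatter. On that basis the step of a number 1.5 percentage points higher from compound 3 to compound 4 (within the scatter) is expected to be small and within the scatter. Compound 4 is therefore estimated to give -10%, with a range from -40% to 25%.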

Compound 4, a percentage reported as activity, at one concentration (the size of the read-out at that concentration, not a potency): -11.7%
Beside the measured number, compound 4's estimate is 1.7 percentage points above it; measured number inside the range.
By their numbers in this assay, from the lowest: compound 2; then compounds 4 and 3 (each within the scatter of the next); then compound 1.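

In this assay, the step of a number 0.2 percentage points lower from compound 3 to compound 4 (within the scatter) shows that, on the amide-type nitrogen, 3-(trifluoromethyl)phenyl and 3,4-dichlorophenyl cannot be told apart, so this position accepts a change of aryl group without a readable shift in the number. Among the compounds shown here, the step of a number 13.9 percentage points higher from compound 2 to compound 4 (beyond the scatter), with hydrogen in place of trifluoromethyl on an aromatic carbon, gives the first modest difference among the aryl groups on this nitrogen, with the 3,5-bis(trifluoromethyl)phenyl of compound 2 giving the lower number, while the step of a number 95.9 percentage points lower from compound 1 to compound 4 (beyond the scatter) is of the same large size as the one already seen for compound 3, so a large gap from compound 1 is now seen with two different aryl groups on the urea. There is no evidence available to explain these differences.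

Still open, going by these compounds, is whether an aryl ring carrying a methoxy or nitrile group, or a cyclohexyl group in place of the aryl ring, would keep the number at this level on the same nitrogen. The compounds shown also leave open how an amide carrying 3-(trifluoromethyl)phenyl directly on its carbonyl carbon would compare with compound 4.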